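A few compounds are considered here, and "the series" means these few. Any claim that something is new, unique, unknown or untested is made for them only; others in the source may bear on it.

Notes on the series, read in a physicochemical assay for solubility, read by HPLC; a higher number here means a more soluble compound, a lower number a less soluble compound: compound 1 (`CC(=O)NC[C@H]1CN(c2ccc(OC[C@@H](O)CNc3ccccc3)c(F)c2)C(=O)O1`) gives 124000 nM and compound 2 (`CC(=O)NC[C@H]1CN(c2ccc(OC[C@@H](O)CNc3ccc(C#N)cc3)c(F)c2)C(=O)O1`) gives 47000 nM while compound 3 (`CC(=O)NC[C@H]1CN(c2ccc(OC[C@@H](O)CNc3cccnc3)c(F)c2)C(=O)O1`) gives 3040000 nM and stands highest of the three. Compound 4 (`CC(=O)NC[C@H]1CN(c2ccc(OC[C@H](O)CNC3CC3)c(F)c2)C(=O)O1`) is still unmeasured. The change is 2-(cyclopropylamino)-1-hydroxyethyl in place of 1-hydroxy-2-((pyridin-3-yl)amino)ethyl on a saturated chain carbon bound to an oxygen on an aromatic ring and amounts to 2-(cyclopropylamino)-1-hydroxyethyl in place of 1-hydroxy-2-((pyridin-3-yl)amino)ethyl on a saturated chain carbon bound to an oxygen on an aromatic ring.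

The closest evidence is two large steps at this site: a 25-fold higher number from compound 1 to compound 3 (1.39 log units; beyond the scatter) and a 65-fold higher number from compound 2 to compound 3 (1.81 log units; beyond the scatter). The modest 2.6-fold lower number from compound 1 to compound 2 (0.42 log units; beyond the scatter) bears on it less directly. Within the data shown here, no measured compound lacks an aromatic ring on the amine nitrogen, so the direction is open and no direct precedent exists. The expected step is a 1.0-fold lower number from compound 3 to compound 4 (0.01 log units; within the scatter) and none beyond the scatter is expected, though with wide uncertainty. For compound 4 the estimate is 3000000 nM with an expected range from 600000 nM to 12000000 nM in this assay.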

Compound 4, solubility: 2200000 nM
Beside the measured number, compound 4's estimate is 1.4-fold (0.13 log units) above it; the measured number falls inside the stated range.
By their numbers in this assay, from the lowest: compound 2; then compound 1; then compounds 4 and 3 (each within the scatter of the next).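

Replacing 1-hydroxy-2-((pyridin-3-yl)amino)ethyl with 2-(cyclopropylamino)-1-hydroxyethyl on a saturated chain carbon bound to an oxygen on an aromatic ring gives, in this assay, a 1.4-fold lower number from compound 3 to compound 4 (0.14 log units; within the scatter), so an aromatic ring on the amine nitrogen is not needed for a number at this level. Set against the 2-anilino-1-hydroxyethyl group, the same group gives an 18-fold higher number from compound 1 to compound 4 (1.25 log units; beyond the scatter), so a large rise at this position is no longer tied to the pyridin-3-yl group alone. No measurement on hand accounts for either step.

Open, on these data alone, is whether other groups on the amine nitrogen, such as an isopropyl group, a longer alkyl chain or a cyclohexyl ring, hold this level. Also open, as far as these compounds go, is how a carboxylic acid at the end of that chain, or a morpholine in place of the amine, would read.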